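The compounds below may be only part of what the source reports. "The series", "measured", "known", "first", "only" and "open" are said of these compounds alone.

The shared core is carried by compound 1 `O=C(Nc1cccc(C(F)(F)F)c1)C1c2ccccc2CCN1C(=O)c1ccc(Cl)cc1`, compound 2 `O=C(Nc1ccccc1O)C1c2ccccc2CCN1C(=O)c1ccc(Cl)cc1` and compound 3 `O=C(Nc1ccccc1C(F)(F)F)C1c2ccccc2CCN1C(=O)c1ccc(Cl)cc1`. In a functional assay on NUGC-3 cells (Homo sapiens) for inhibition, read by sulforhodamine B assay, with a stated time of 48 h (on this read-out lower numbers stand for stronger inhibition of growth and higher numbers for weaker inhibition of growth), compound 1 reports only a limit of the assay, > 10000 nM. Compound 2 likewise reports a limit, > 10000 nM. Compound 3 also stands at a limit, > 10000 nM. Compound 3 thus sits at the limit of > 10000 nM in this assay, at which 3 of the 3 values shown sit. The measured steps a step that the two limits leave unreadable from compound 1 to compound 2, a step that the two limits leave unreadable from compound 1 to compound 3 and a step that the two limits leave unreadable from compound 2 to compound 3 give no readable size. Compound 4 `O=C(Nc1ccc(O)cc1)C1c2ccccc2CCN1C(=O)c1ccc(Cl)cc1` differs from compound 3 by 4-hydroxyphenyl in place of 2-(trifluoromethyl)phenyl on an amide-type nitrogen. The closest comparison, a step that the two limits leave unreadable from compound 1 to compound 2, offers no size either, so no step beyond the scatter can be foreseen. Compound 4 is expected to give 15000 nM, in the range 4000 nM to 60000 nM, most likely again as a limit. The expected step is a step that the limit leaves unreadable from compound 3 to compound 4.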

Compound 4, concentration for 50% growth inhibition: > 10000 nM
Compound 4 was reported as a limit; the forecaster's own chance of this, stated with the estimate: 80%; the middle value is on the limit's open side.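

Compound 4 stands at a limit in this assay, as do compound 1, compound 2 and compound 3, so none of its steps to them can be read: the limit of > 10000 nM in this assay, at which 4 of the 4 values shown sit.

The compounds shown leave open whether changing the group on the amide nitrogen affects growth inhibition at all.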